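Working notes: a trifluoromethoxy exchange in the series

The source may report more compounds than this note shows. Statements on the series, on what has been measured and on what is new or still open speak of the compounds shown alone.

In a functional assay on CWR22R cells (Homo sapiens) for antiproliferative activity, read by propidium iodide staining, with a stated time of 96 h (on this read-out higher numbers stand for weaker inhibition and lower numbers for stronger inhibition), compound 1 (`CC(O)(CSc1ccc(S(F)(F)(F)(F)F)cc1)C(=O)Nc1ccc(C#N)cc1C(F)(F)F`) gives 13200 nM, compound 2 (`CC(O)(CSc1ccc(S(F)(F)(F)(F)F)cc1)C(=O)Nc1ccc(S(F)(F)(F)(F)F)cc1`) gives 24400 nM and compound 3 (`CC(O)(CSc1cccc(S(F)(F)(F)(F)F)c1)C(=O)Nc1ccc(S(F)(F)(F)(F)F)cc1`) gives 17700 nM. Compound 2 lies within the scatter of both others, so the three values show no order. The change from compound 2 to compound 4 (`CC(O)(CSc1ccc(OC(F)(F)F)cc1)C(=O)Nc1ccc(S(F)(F)(F)(F)F)cc1`) is a group of 5 heavy atoms (1 carbon, 1 oxygen, 3 fluorine; no ring) in place of a group of 6 heavy atoms (5 fluorine, 1 sulfur; no ring), on an aromatic carbon, on an aromatic carbon, para to a large group. Going by the values given here, no measured step covers this exchange, so the expectation rests only on that narrow spread, with compound 2 at 24400 nM. No shift beyond the scatter is expected in this assay. The expected step is a 1.2-fold lower number from compound 2 to compound 4 (0.09 log units; within the scatter). For compound 4 the estimated value is 20000 nM, with an expected range of 9000 nM to 42000 nM.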

Compound 4, half-maximal inhibitory concentration: 14900 nM
For compound 4 the middle estimate is 1.3-fold (0.13 log units) above the measured one; measured number inside the range.
By their numbers in this assay, from the lowest: compounds 1, 4, 3 and 2 (each within the scatter of the next).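

In this assay, trifluoromethoxy in place of the group of 5 fluorine and 1 sulfur, on an aromatic carbon para to a large group, gives a 1.6-fold lower number from compound 2 to compound 4 (0.21 log units; within the scatter). This single-place step shows that the exchange, with its added hydrogen-bond acceptor, brings no shift beyond the scatter at this position. No measurement offered here explains the result.

On these data alone, whether an amine or a methoxy group at this place would hold the same level remains open. So does whether trifluoromethoxy behaves alike alongside the nitrile and trifluoromethyl groups of compound 1.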